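Hydroxy in Place of Imidazolyl: An Untested Analogue

The compounds below may be only part of what the source reports. "The series", "measured", "known", "first", "only" and "open" are said of these compounds alone.

The two measured compounds, tested in a functional assay on K562 cells (Homo sapiens) for antiproliferative activity, read by MTT assay, with a stated time of 24 h; on this read-out higher numbers stand for weaker inhibition and lower numbers for stronger inhibition:
compound 1, `COc1cc(OC)c(OC)cc1/C=C/C(=O)c1ccc(OC)c2c1OC(C)(C)C=C2`, gives > 10000 nM.
compound 2, `COc1ccc(C(=O)/C=C/c2ccc(-n3ccnc3)cc2)c2c1C=CC(C)(C)O2`, gives > 10000 nM.

Both of these readings are limits rather than numbers. Compound 2 therefore stands at the limit of > 10000 nM in this assay, at which 2 of the 2 values shown sit, and nothing in these data separates it from compound 1 or sets a scale for how strong either compound actually is. Compound 3, `COc1ccc(C(=O)/C=C/c2ccc(O)cc2)c2c1C=CC(C)(C)O2`, has not been measured. It differs from compound 2 in one place: hydroxy in place of 1H-imidazol-1-yl on an aromatic carbon. Among the measured compounds shown here, no step between measured compounds is available to calibrate this change, and both measured values are limits, so the size and direction of the step can only be estimated. The expected step is a step that the limit leaves unreadable from compound 2 to compound 3, essentially none beyond the scatter. Compound 3 is estimated at 15000 nM, within a range from 4000 nM to 50000 nM.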

Compound 3, half-maximal inhibitory concentration: > 10000 nM
Compound 3: only a limit was reported; the forecaster's own chance of this, stated with the estimate: 60%; the middle value lies beyond the limit too.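

No step can be read from compound 2 to compound 3, because both readings are limits rather than numbers: the limit of > 10000 nM in this assay, at which 3 of the 3 values shown sit.

The compounds shown leave open how strong each one actually is, and whether hydroxy in place of 1H-imidazol-1-yl changes the activity at all.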